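The source may hold more compounds than are shown below. What is called first, only, known or untested is meant among the compounds shown, and "the series" means these compounds.

Measured so far:
Compound 1 `COc1cc(NC(C)CCCNC(=O)CCC(=O)NCCCC(C)Nc2cc(OC)cc3cccnc23)c2ncccc2c1` gives 2820 nM
Compound 2 `COc1cc(NC(C)CCCNC(=O)/C=C/C(=O)NCCCC(C)Nc2cc(OC)cc3cccnc23)c2ncccc2c1` gives 9300 nM

In a functional assay on MCF7 cells (Homo sapiens) for antiproliferative activity, read by MTT assay, with a stated time of 72 h (a lower number here means a stronger inhibitor, a higher number a weaker inhibitor), compound 2 gives 9300 nM, the highest of the two numbers; compound 1 gives 2820 nM, a lower number by a margin beyond the scatter. Compound 3 `COc1cc(NC(C)CCCNC(=O)/C=C\C(=O)NCCCC(C)Nc2cc(OC)cc3cccnc23)c2ncccc2c1` differs from compound 2 in one respect only: the two compounds have the same atoms and bonds; at least one stereo element is drawn with a configuration in one of them and without one in the other: 1 of 3 stereo elements differ; a double bond is drawn E in compound 2 and Z in compound 3. Among the measured compounds shown here, no measured pair shows what such a change does, so the step is expected to be modest, its direction uncertain, with a slight lean toward a lower number. Compound 3 is expected to give 6500 nM, within a range of 2500 nM to 16000 nM. The step this estimate implies is a 1.4-fold lower number from compound 2 to compound 3 (0.16 log units; within the scatter).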

Compound 3, half-maximal inhibitory concentration: 3140 nM
Compound 3: middle estimate off by 2.1-fold (0.32 log units), on the high side; the measured number falls inside the stated range.
By their numbers in this assay, from the lowest: compounds 1 and 3 (each within the scatter of the next); then compound 2.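

In this assay, among the compounds shown here, the geometry of the double bond alone makes a difference, with atoms and bonds unchanged: a 3.0-fold lower number from compound 2 to compound 3 (0.47 log units; beyond the scatter) is a step that goes with nothing but the switch from E to Z. The earlier compounds could not show this, and compound 3 now stands within the scatter of compound 1, so a double bond at this place does not by itself go with the higher number. The reading carries one caveat: the fact that one of compounds 2 and 3 is drawn with a defined configuration and the other without, at the place where they differ. Still open, from the compounds shown here alone, is whether a longer chain or an amine at this place would move the number further.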